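The compounds below may be only part of what the source reports. "The series", "measured", "known", "first", "only" and "open" are said of these compounds alone.

Working notes on the present series.

For the measured compounds named here, compound 1 `Cc1cc(C(=O)O)ccc1CN1CCC[C@H](O[C@H](CO)c2cc(Cl)nc(Cl)c2)[C@@H]1c1ccccc1` carries the lowest of the two numbers measured so far: in an assay on isolated protein for activation of cGMP-dependent protein kinase 1 (Homo sapiens), read by ADP-Glo, with stated times of 30 min and 2 h, in the presence of a further agent that is not named here (a higher number here means that more compound is needed for the effect, a lower number that less compound is needed), compound 1 gives 2400 nM. Going by the values given here, the only other measured member, compound 2 `Cc1cc(C(=O)O)ccc1CN1CCC[C@@]2(C[C@@H](c3ccccc3)CO2)[C@@H]1c1ccccc1`, gives 43000 nM in this assay, a gap that lies beyond the usual scatter, so compound 1 is the more potent of the two on the present evidence.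

Compound 3 `Cc1cc(C(=O)O)ccc1CN1CCC[C@H](O[C@H](CO)c2cccc(Cl)c2)[C@@H]1c1ccccc1` is the next member to be measured. Relative to compound 1 the change is 3-chlorophenyl in place of 2,6-dichloropyridin-4-yl on a saturated chain carbon bound to an oxygen on a saturated carbon and a saturated chain carbon. Among the compounds with values here, no measured pair shows this kind of exchange, so there is no prior step to draw on; the change replaces one aromatic ring by another at the same position, leaving the rest of the shared core intact. A step of modest size in this assay, not clearly beyond the scatter in either direction, is therefore expected for compound 3, and the estimate for compound 3 is 3200 nM with a range from 900 nM to 12000 nM, which means an expected step of a 1.3-fold higher number from compound 1 to compound 3 (0.12 log units; within the scatter).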

Compound 3, half-maximal effective concentration: 1300 nM
Beside the measured number, compound 3's estimate is 2.5-fold (0.39 log units) above it; low and high end bracket the measured number.
By their numbers in this assay, from the lowest: compounds 3 and 1 (each within the scatter of the next); then compound 2.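

The exchange of 2,6-dichloropyridin-4-yl for 3-chlorophenyl, on a saturated chain carbon bound to an oxygen on a saturated carbon and a saturated chain carbon, gives a 1.8-fold lower number from compound 1 to compound 3 (0.27 log units; within the scatter) in this assay. This single pair shows that a ring of carbon only, with a single chlorine, can stand at this position in place of a ring with a hetero atom and two chlorines, with no step beyond the scatter. No measurement at hand bears on why the two rings read alike.

Open, from the compounds shown here alone, is how a plain phenyl without chlorine, or a ring carrying an amine or a carboxylic acid, would read at this place. Also open, going by these compounds, is whether a step beyond the scatter can be reached at this position at all.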